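A few compounds are considered here, and "the series" means these few. Any claim that something is new, unique, unknown or untested is made for them only; others in the source may bear on it.

In a functional assay on A2780 cells (Homo sapiens) for inhibition, read by MTT assay, with a stated time of 72 h (a lower number here means a stronger inhibitor, a higher number a weaker inhibitor), three compounds that share one core have been measured. Compound 1 `O=C1/C(=C\c2ccccc2)c2c(ncn2COCc2ccccc2)CCN1Cc1ccccc1` gives 20400 nM, compound 2 `Cc1cc(C)cc(CN2CCc3ncn(COCc4ccccc4)c3/C(=C/c3ccccc3)C2=O)c1` gives 31300 nM, and compound 3 `Cc1cccc(CN2CCc3ncn(COCc4ccccc4)c3/C(=C/c3ccccc3)C2=O)c1` gives 26300 nM. Compound 3 therefore stands level with the other two, since a 1.3-fold higher number from compound 1 to compound 3 (0.11 log units; within the scatter) and a 1.2-fold lower number from compound 2 to compound 3 (0.08 log units; within the scatter) both lie within the scatter.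

Compound 4 `O=C1/C(=C\c2ccccc2)c2c(ncn2COCc2ccccc2)CCN1Cc1ccc(-c2ccccc2)cc1` changes the group on a saturated chain carbon bound to an amide-type nitrogen in a ring: 4-phenylphenyl in place of 3-methylphenyl on a saturated chain carbon bound to an amide-type nitrogen in a ring. Among the compounds with values here, two measured steps bear on this place, a 1.3-fold higher number from compound 1 to compound 3 (0.11 log units; within the scatter) and a 1.5-fold higher number from compound 1 to compound 2 (0.19 log units; within the scatter). Each adds methyl groups to the phenyl, and neither moves the number beyond the scatter. Within the data shown here, no measured compound carries 4-phenylphenyl, however, so these steps are only a weak guide and the range must stay wide. No step beyond the scatter is expected in this assay, in either direction. The expected change is small, a 1.1-fold lower number from compound 3 to compound 4 (0.04 log units; within the scatter). For compound 4 the estimated value is 24000 nM, with an expected range of 10000 nM to 50000 nM.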

Compound 4, half-maximal inhibitory concentration: 48300 nM
Compound 4: the middle estimate sits 2.0-fold (0.30 log units) below what was measured; low and high end bracket the measured number.
By their numbers in this assay, from the lowest: compounds 1, 3, 2 and 4 (each within the scatter of the next, the first and the last beyond it).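

Placing a second aromatic ring at this position, on a saturated chain carbon bound to an amide-type nitrogen in a ring, gives the only step in this set that lies beyond the scatter: a 2.4-fold higher number from compound 1 to compound 4 (0.37 log units; beyond the scatter) in this assay. Measured against the methyl-bearing groups, the same 4-phenylphenyl stays within the scatter, with a 1.8-fold higher number from compound 3 to compound 4 (0.26 log units; within the scatter) and a 1.5-fold higher number from compound 2 to compound 4 (0.19 log units; within the scatter), so it stands apart only from plain phenyl. Nothing available here explains that modest step.

Every group compared at this position is built only of carbon, so the compounds shown leave open what a group carrying an amine or a carboxylic acid would do here. They also leave open whether any change at this position can give a lower number than compound 1 does.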